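A few compounds are considered here, and "the series" means these few. Any claim that something is new, unique, unknown or untested is made for them only; others in the source may bear on it.

Compound 1 `CC[C@@H]1CN(c2scnc2-c2nc3ccccc3[nH]2)CCN1C(=O)Cn1cnc2cccnc21` gives, in a functional assay on U2OS cells for antagonist activity at C-X-C chemokine receptor type 3 (Homo sapiens), read by beta-arrestin recruitment (on this read-out lower numbers stand for stronger inhibition and higher numbers for weaker inhibition), 604 nM.
Compound 2 `COc1ncc(-c2nc(C(F)(F)F)sc2N2CCN(C(=O)Cn3cnc4cccnc43)[C@H](C)C2)cn1` gives 177 nM in this assay.
Compound 3 `COc1ncc(-c2nc(C(F)(F)F)sc2N2CCN(C(=O)Cn3nc(C)nc3C)[C@H](C)C2)cn1` gives 558 nM in this assay.

Compound 3 holds the second highest of these three numbers: the change at the chain carbon bound to the carbonyl gave a 3.2-fold higher number from compound 2 to compound 3 (0.50 log units; beyond the scatter), whereas the numbers of compound 3 and compound 1 lie within the scatter of each other. Compound 4 `Cc1nc(C)n(CC(=O)N2CCN(c3sc(C(F)(F)F)nc3-c3cnc(OC4CCC4)nc3)C[C@H]2C)n1` differs from compound 3 by cyclobutyl in place of methyl on an oxygen on an aromatic ring. Among the measured compounds shown here, no measured step touches this place, since the only step known concerns a different part of the molecule, so there is no basis for expecting a step beyond the scatter; the expected step is a 1.2-fold lower number from compound 3 to compound 4 (0.09 log units; within the scatter). Compound 4 is therefore estimated at 450 nM in this assay, within a range of 150 nM to 1400 nM.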

Compound 4, half-maximal inhibitory concentration: 78 nM
Compound 4: the middle estimate sits 5.8-fold (0.76 log units) above what was measured; measured number below the stated range.
By their numbers in this assay, from the lowest: compound 4; then compound 2; then compounds 3 and 1 (each within the scatter of the next).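

Putting cyclobutyl in place of methyl on the oxygen on the aromatic ring gives a 7.2-fold lower number from compound 3 to compound 4 (0.85 log units; beyond the scatter) in this assay. This shows that the group on that oxygen, a place the earlier step did not touch, can shift the number well beyond the scatter, and that the larger group is accepted there. Nothing shown explains why the number falls.

Going by these compounds, it remains open whether the ring matters or only the added carbon, which a straight butyl chain on that oxygen could separate. On these data alone, whether the change carries over to other groups on the chain carbon bound to the carbonyl is also open.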